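The source may hold more compounds than are shown below. What is called first, only, known or untested is meant among the compounds shown, and "the series" means these compounds.

The study concerns a small set of cyclopropane compounds that all carry the same trimethoxyphenyl-bearing core, tested in a functional assay on SW480 cells (Homo sapiens) for cytotoxicity, read by MTT assay, with a stated time of 48 h; a lower number here means a stronger inhibitor, a higher number a weaker inhibitor. Compound 1 `CCOC(=O)[C@]1(C(=O)Nc2ccccc2)C[C@H]1c1cc(OC)c(OC)c(OC)c1` is the ester of the series; in this assay compound 1 reaches only the limit of > 100000 nM. Compound 2 `COc1cc([C@H]2C[C@@]2(CO)C(=O)Nc2ccccc2)cc(OC)c1OC` carries a hydroxymethyl group and an anilino amide; in this assay compound 2 likewise reaches only the limit of > 100000 nM. Among the measured compounds shown here, compound 3 `COc1cc([C@@H]2C[C@]2(CO)C(=O)NCc2ccc(C)cc2)cc(OC)c1OC` differs in its amide, bearing a 4-methylbenzyl group on the nitrogen, and in this assay compound 3 gives 26800 nM, the only finite number among the three, since the limit of > 100000 nM in this assay, at which 2 of the 3 values shown sit, holds the other two.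

Compound 4 `COc1cc([C@@H]2C[C@]2(CO)C(=O)Nc2ccccc2)cc(OC)c1OC` is the next step from compound 3: phenyl in place of 4-methylbenzyl on an amide-type nitrogen. For the measured compounds named here, since no measured pair differs in a single place, no step size is known in advance. Compound 2 already carries the anilino amide and gives only a limit, so the change is expected to weaken inhibition well beyond the scatter, with a 4.5-fold higher number from compound 3 to compound 4 (0.65 log units; beyond the scatter). Compound 4 is therefore expected to give about 120000 nM, plausibly between 40000 nM and 400000 nM, and quite possibly only a limit.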

Compound 4, half-maximal inhibitory concentration: 33300 nM
Estimate against measurement, compound 4: 3.6-fold (0.56 log units) above; measured number outside the range, below it.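

In this assay, the change on the amide-type nitrogen makes no clear difference: the step is a 1.2-fold higher number from compound 3 to compound 4 (0.09 log units; within the scatter), so phenyl and 4-methylbenzyl cannot be told apart here. The anilino amide does not by itself give the weak result, since the change is an at least 3.0-fold lower number from compound 2 to compound 4 (0.47 log units; beyond the scatter), and this step rests on configuration alone: the fact that compounds 2 and 4 differ only in the configuration as drawn. Hydroxymethyl in place of ethoxycarbonyl goes with an at least 3.0-fold lower number from compound 1 to compound 4 (0.47 log units; beyond the scatter), and the sizes of these last two steps are only bounds, set by a limit: the limit of > 100000 nM in this assay, at which 2 of the 4 values shown sit.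

The compounds shown leave open how an unsubstituted benzyl group or a longer chain on the amide nitrogen would compare. They also leave open whether an amine or a carboxylic acid in place of hydroxymethyl would move the number, and how the mirror image of compound 3 would behave.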